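Adding a Second Hydroxy Group on a Different Core

The source may report more compounds than this note shows. Statements on the series, on what has been measured and on what is new or still open speak of the compounds shown alone.

Compound 1 `O=C1/C(=C/c2ccccc2)CCC/C1=C\c1cccc(O)c1`: 65.1%
Compound 2 `O=C1/C(=C/c2ccccc2)CCC/C1=C\c1ccc(O)c(O)c1`: 90.7%
Compound 3 `O=C(/C=C(O)/C=C/c1cccc(O)c1)c1cc(Cl)ccc1O`: 62.4%

Of the compounds shown here, three have been measured in an assay on isolated protein for inhibition of Alpha glucosidase (Homo sapiens), with stated times of 5 min and 15 min, tested at 50 uM; on this read-out lower numbers stand for less inhibition and higher numbers for more inhibition at the one concentration tested (going by the name of the read-out). From compound 1 to compound 2 the change is hydroxy in place of hydrogen on an aromatic carbon, and it brings a number 25.6 percentage points higher from compound 1 to compound 2 (beyond the scatter). Compound 3 is built on another core; the difference between the two cores is not broken down here. In this assay compound 3 and compound 1 give numbers within the scatter of each other, while compound 2 stands beyond the scatter above both.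

Compound 4 `O=C(/C=C(O)/C=C/c1ccc(O)c(O)c1)c1cc(Cl)ccc1O` has not yet been measured. It differs from compound 3 by hydroxy in place of hydrogen on an aromatic carbon, the same change that takes compound 1 to compound 2, placed in the same surroundings. A step of similar size is expected, a number 17.6 percentage points higher from compound 3 to compound 4 (beyond the scatter), because the earlier step of a number 25.6 percentage points higher from compound 1 to compound 2 (beyond the scatter) came from this very change, though that rests on a single example and the core of compound 3 is not the core of compound 1. The estimate for compound 4 in this assay is 80%, with a likely range from 65% to 92%.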

Compound 4, a percentage reported as inhibition, at one concentration (the size of the read-out at that concentration, not a potency): 85.6%
Compound 4: middle estimate off by 5.6 percentage points, on the low side, and the stated range covers the measured number.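

In this assay, hydroxy in place of hydrogen on an aromatic carbon, ortho to a hydroxy group, gives a number 23.2 percentage points higher from compound 3 to compound 4 (beyond the scatter) on the second core. Set beside the earlier step, the change carries from one core to the other with no difference that can be told in size: the same change on two cores in this assay, a number 25.6 percentage points higher (beyond the scatter) from compound 1 to compound 2 and a number 23.2 percentage points higher (beyond the scatter) from compound 3 to compound 4, 2.4 percentage points apart, within the scatter of two such steps. Among the compounds shown here, this shows that the step held on these two cores at the one concentration tested, but with only two pairs, each with the new hydroxy in the same surroundings, it does not show that the step would hold on a third core or at another place on the ring, and it gives no measure of potency.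

The compounds shown leave open whether a methoxy group, an amine or a carboxylic acid in that same place would give a step of similar size. For the compounds shown here, they also leave open what the core alone contributes, as no pair among them differs only in the core.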